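Replacing Vinyl with an Amide Chain on the Shared Core

This account rests on a few compounds, and the source may have more. Where it says the series, first, only, none or still open, it means among the compounds named here.

Compound 1, `C=CCn1nc(-c2cccnc2)c2ccccc2c1=O`: 2140 nM
Compound 2, `O=C(O)Cn1nc(-c2cccnc2)c2ccccc2c1=O`: > 100000 nM (an assay limit, not a number)

Both were tested in a functional assay (trachea) with Cavia porcellus as the target; on this read-out higher numbers stand for weaker inhibition and lower numbers for stronger inhibition. Compound 1 gives 2140 nM and holds the only number shown. For compound 2 the outcome is only a limit of the assay, > 100000 nM. That limit is the limit of > 100000 nM in this assay, at which 1 of the 2 values shown sits. Among the measured compounds shown here, the single measured step, an at least 46-fold higher number from compound 1 to compound 2 (1.66 log units; beyond the scatter), is a large loss. Compound 3, `CC(C)NC(=O)CCCn1nc(-c2cccnc2)c2ccccc2c1=O`, differs from compound 1 by 2-(isopropylcarbamoyl)ethyl in place of vinyl on a saturated chain carbon bound to an aromatic nitrogen. The measured step bears on this only in part: there a carboxy entered at the same place, whereas here a 2-(isopropylcarbamoyl)ethyl enters, bringing 1 hydrogen-bond donor and 1 hydrogen-bond acceptor and no net charge. A weakening beyond the scatter is expected, but much smaller than the measured step. Compound 3 is therefore estimated at 6000 nM, within 1500 nM to 30000 nM. The expected step in this assay is a 2.8-fold higher number from compound 1 to compound 3 (0.45 log units; beyond the scatter).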

Compound 3, half-maximal inhibitory concentration: 64600 nM
For compound 3 the middle estimate is 11-fold (1.03 log units) below the measured one; measured number above the stated range.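

In this assay, the large loss at this position is not limited to carboxy: 2-(isopropylcarbamoyl)ethyl, which carries no net charge, also weakens the compound, with a 30-fold higher number from compound 1 to compound 3 (1.48 log units; beyond the scatter). Set against the carboxy compound, the comparison gives an at least 1.5-fold lower number from compound 2 to compound 3 (0.18 log units; that floor lies within the scatter), so the two replacements cannot be put in order. Compound 2 has only a limit of the assay, not a number: the limit of > 100000 nM in this assay, at which 1 of the 3 values shown sits.

The compounds shown leave open whether the loss in compound 3 follows from its longer chain, its amide or its isopropyl end, since all three enter together. A plain butyl chain and a primary amide on a short chain, each at this same place, would help separate these parts.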